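Piperidine substituent trimmed: expectation for compound 3

The source may hold more compounds than are shown below. What is called first, only, known or untested is meant among the compounds shown, and "the series" means these compounds.

Measured so far in a functional assay on NCI-H1975 cells (Homo sapiens) for inhibition, read by CellTiter-Glo, with a stated time of 72 h; a lower number here means a stronger inhibitor of growth, a higher number a weaker inhibitor of growth:
compound 1 `C=CC(=O)Nc1cc(Nc2ncc(Cl)c(Nc3ccccc3S(=O)(=O)C(C)C)n2)c(OC)cc1N1CCC(N2CCN(C)CC2)CC1`: 23 nM
compound 2 `C=CC(=O)Nc1cc(Nc2ncc(Cl)c(Nc3ccccc3S(=O)(=O)C(C)C)n2)c(OC)cc1N1CCN(C2CCCCC2)CC1`: 77 nM

Compound 1 gives the lowest number of the two; compound 2 sits higher, and the gap lies beyond the scatter of this assay. Among the compounds with values here, no single-point step between the two measured compounds is available, so the only guide is the pair itself and the structural change.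

Compound 3 `C=CC(=O)Nc1cc(Nc2ncc(Cl)c(Nc3ccccc3S(=O)(=O)C(C)C)n2)c(OC)cc1N1CCCCC1` differs from compound 1 by hydrogen in place of 4-methylpiperazin-1-yl on a saturated ring carbon, leaving a plain six-membered nitrogen ring on the shared core.

Both measured compounds carry a second basic ring at that position, and compound 3 carries none; on that basis a modest loss is expected, a step of a 2.8-fold higher number from compound 1 to compound 3 (0.45 log units; beyond the scatter) from compound 1, probably beyond the scatter but not large. Compound 3 is therefore estimated at 65 nM, with a range of 15 nM to 280 nM.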

Compound 3, concentration for 50% growth inhibition: 240 nM
Estimate against measurement, compound 3: 3.7-fold (0.57 log units) below, and the stated range covers the measured number.
By their numbers in this assay, from the lowest: compound 1; then compound 2; then compound 3.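

In this assay, taking 4-methylpiperazin-1-yl off the saturated ring carbon gives a 10-fold higher number from compound 1 to compound 3 (1.02 log units; beyond the scatter), a large step, showing that the group carried at this position matters to growth inhibition. Replacing 4-cyclohexylpiperazin-1-yl on the aromatic carbon with piperidin-1-yl gives a 3.1-fold higher number from compound 2 to compound 3 (0.49 log units; beyond the scatter), a modest step, so compound 3, with its plain six-membered ring, is the weakest inhibitor of growth of the three. Nothing measured here accounts for either step.

The compounds shown do not separate the contribution of the whole 4-methylpiperazin-1-yl ring from that of any single atom in it. From the compounds shown here alone, whether a smaller group on the same saturated ring carbon, such as dimethylamino, morpholin-4-yl or hydroxyl, would recover the number of compound 1 remains open.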